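This account rests on a few compounds, and the source may have more. Where it says the series, first, only, none or still open, it means among the compounds named here.

Measured so far in a functional assay on SF-268 cells (Homo sapiens) for inhibition, read by sulforhodamine B assay, with a stated time of 48 h; on this read-out higher numbers stand for weaker inhibition of growth and lower numbers for stronger inhibition of growth:
compound 1 `COc1cc2cc(Oc3ccc(NC(=O)Nc4cccc(C(F)(F)F)c4)cc3)c(C)nc2cc1OC`: 15500 nM
compound 2 `COc1cc2cc(Oc3ccc(NC(=O)Nc4ccc(Cl)c(C(F)(F)F)c4)cc3)c(C)nc2cc1OC`: 6340 nM

Within the data shown here, compound 2 holds the lower of the two numbers; its nearest neighbour is compound 1, and the one measured step, a 2.4-fold lower number from compound 1 to compound 2 (0.39 log units; beyond the scatter), is a modest gain lying beyond the scatter, brought by chloro in place of hydrogen on an aromatic carbon.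

Next in line is compound 3 `COc1cc2cc(Oc3ccc(NC(=O)Nc4ccc(Cl)c(Cl)c4)cc3)c(C)nc2cc1OC`. Against compound 2 the change is chloro in place of trifluoromethyl on an aromatic carbon. Among the measured compounds shown here, no measured step covers an exchange of trifluoromethyl for chloro; the single step known so far concerns only the chloro that compound 2 and compound 3 share, so it gives no direction for this move. The expectation for compound 3 is therefore a number close to that of compound 2, with no step beyond the scatter, its mid-point set a little higher for caution. For compound 3 the estimate is 8000 nM, with a range of 3000 nM to 22000 nM. Expressed as a step this estimate means a 1.3-fold higher number from compound 2 to compound 3 (0.10 log units; within the scatter) for compound 3.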

Compound 3, concentration for total growth inhibition: > 100000 nM
Compound 3: a limit, no number (the forecaster's own chance of this, stated with the estimate: 5%); at least 12-fold (1.09 log units) between middle value and limit.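

In this assay compound 3 stands as a limit and not as a number: the limit of > 100000 nM in this assay, at which 1 of the 3 values shown sits.
At this place, on an aromatic carbon ortho to a chloro group, chloro in place of trifluoromethyl is far from a neutral exchange: the move gives an at least 15-fold higher number from compound 2 to compound 3 (1.19 log units; beyond the scatter) and so loses the growth inhibition that compound 2 shows. The earlier chloro gain therefore does not carry over to every partner group, since the 3,4-dichlorophenyl compound falls behind the compound lacking the added chloro, with an at least 6.4-fold higher number from compound 1 to compound 3 (0.80 log units; beyond the scatter) as the step.

Open, from the compounds shown here alone, is how a methyl, a methoxy or a nitrile would behave at this same place. Also open, going by these compounds, is whether the 4-chloro group still gives a gain with any of these groups in place of trifluoromethyl.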